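From Cycloheptyl to Octyl on the Shared Core

The source may report more compounds than this note shows. Statements on the series, on what has been measured and on what is new or still open speak of the compounds shown alone.

Measured in a physicochemical assay for solubility, at pH 7.4; on this read-out lower numbers stand for lower solubility and higher numbers for higher solubility:
- Compound 1 `CC1(c2nc(-c3ccc(CNC(=O)[C@H]4NCC[C@@H]4O)cc3)no2)CCCCC1`: > 50 ug/mL
- Compound 2 `O=C(NCc1ccc(-c2noc(C3CCCCCC3)n2)cc1)[C@H]1NCC[C@@H]1O`: > 50 ug/mL

Compound 2 gives > 50 ug/mL, which is a limit of the assay and not a number. Compound 1 gives > 50 ug/mL, which is also a limit. Together they make up the whole record so far: the limit of > 50 ug/mL in this assay, at which 2 of the 2 values shown sit.

Compound 3 `CCCCCCCCc1nc(-c2ccc(CNC(=O)[C@H]3NCC[C@@H]3O)cc2)no1` keeps the shared core of compound 2 and puts octyl in place of cycloheptyl on an aromatic carbon. The seven-membered ring leaves, and a group with no ring enters.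

Going by the values given here, only one measured step bears on this change, a step that the two limits leave unreadable from compound 1 to compound 2. It exchanges one ring group for another at the same kind of carbon and gives no size to carry over. Among the compounds with values here, no measured step replaces a ring with an open chain. In this assay no step beyond the scatter is therefore expected, and no direction can be read, although the range allows for a fall. The estimated move is a number no higher from compound 2 to compound 3 (the limit leaves the size open). For compound 3 the expected value is 50 ug/mL, with an estimated range from 20 ug/mL to 100 ug/mL.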

Compound 3, solubility: 4 ug/mL
Compound 3: middle estimate off by 13-fold (1.10 log units), on the high side, and the stated range ends above it.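

In this assay, the group on this aromatic carbon now makes a visible difference: octyl in place of cycloheptyl gives an at least 12-fold lower number from compound 2 to compound 3 (1.09 log units; beyond the scatter), and octyl in place of 1-methylcyclohexyl gives an at least 12-fold lower number from compound 1 to compound 3 (1.09 log units; beyond the scatter). The two ring compounds had shown no readable difference, whereas compound 3, whose group has no ring, is the only one of the three with a value that is a number and not a limit, and the groups exchanged from compound 2 to compound 3 carry no hydrogen-bond donors, no hydrogen-bond acceptors and no net charge. The true size of both steps remains unknown, and each printed size is only a minimum, because the two ring compounds sit at a limit of the assay: the limit of > 50 ug/mL in this assay, at which 2 of the 3 values shown sit.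

The three compounds leave open whether the fall belongs to the loss of the ring or to the length of the chain, a question on which a shorter chain such as butyl, or a larger ring such as cyclooctyl, would bear. They also leave open how far the two ring compounds lie beyond their limit, and what an amine or a carboxylic acid carried on the octyl chain would do to this read-out.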